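The compounds below may be only part of what the source reports. "The series", "measured", "known", "first", "only" and "open" are said of these compounds alone.

Measured so far:
Compound 1 `O=C(C1CC1)N1CCN(c2nc(=O)c3cc(C(F)(F)F)cc([N+](=O)[O-])c3s2)CC1`: in an ADME assay on Vero cells (Chlorocebus sabaeus) for cytotoxicity, read by MTT assay, with a stated time of 72 h (on this read-out higher numbers stand for lower toxicity in this test and lower numbers for higher toxicity in this test), compound 1 gives > 125000 nM, which is a limit of the assay and not a number.
Compound 2 `CC(C)CC(=O)N1CCN(c2nc(=O)c3cc(C(F)(F)F)cc([N+](=O)[O-])c3s2)CC1`: in this assay compound 2 gives > 125000 nM, again a limit of the assay.

Compound 2 therefore stands only at the limit of this test, with no number of its own. The step that the two limits leave unreadable from compound 1 to compound 2 is one that the two limits leave unreadable, since (the limit of > 125000 nM in this assay, at which 2 of the 2 values shown sit). Nothing is known here beyond that both values rest at the ceiling of the assay.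

Compound 3 `CC(C)(C)C1CCC(C(=O)N2CCN(c3nc(=O)c4cc(C(F)(F)F)cc([N+](=O)[O-])c4s3)CC2)CC1` differs from compound 2 by 4-(tert-butyl)cyclohexyl in place of isobutyl on a carbonyl carbon. Among the measured compounds shown here, the only measured step that bears on this change, the one from compound 1 to compound 2, gives no readable size, so no direction or magnitude can be drawn from it for the move to compound 3; both values behind it sit at the limit. Compound 3 is accordingly expected to give 125000 nM, within a range of 50000 nM to 250000 nM. The step of a number no higher from compound 2 to compound 3 (the limit leaves the size open) is the expected consequence, most likely again reported only as a limit.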

Compound 3, half-maximal cytotoxic concentration: > 125000 nM
Compound 3: only a limit was reported; the forecaster's own chance of this, stated with the estimate: 65%; the middle value sits exactly at the limit.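

In this assay compound 3 gives > 125000 nM, which is a limit of the assay and not a number. Among the compounds shown here, no step among compound 1, compound 2 and compound 3 can be read: the limit of > 125000 nM in this assay, at which 3 of the 3 values shown sit. The compounds shown leave open whether cyclopropyl, isobutyl and 4-(tert-butyl)cyclohexyl on the carbonyl carbon differ at all in half-maximal cytotoxic concentration.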